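The source may report more compounds than this note shows. Statements on the series, on what has been measured and on what is new or still open speak of the compounds shown alone.

Compound 3 `CCC(O)(CC)CC(=O)O[C@H](CC=C(C)C)C1=CC(=O)c2c(O)ccc(O)c2C1=O` gives 52000 nM in a functional assay on HeLa cells (Homo sapiens) for cytotoxicity, read by MTT assay (a higher number here means a weaker inhibitor, a lower number a stronger inhibitor), the higher of the two numbers in hand; compound 2 `CC(C)=CC[C@@H](OC[C@@H](C)O)C1=CC(=O)c2c(O)ccc(O)c2C1=O` gives 22500 nM, the gap being a 2.3-fold higher number from compound 2 to compound 3 (0.36 log units; beyond the scatter). Compound 1 `CC(C)=CC[C@@H](OC(=O)c1ccoc1)C1=CC(=O)c2c(O)ccc(O)c2C1=O` reaches only the limit of > 100000 nM in this assay, so the steps of an at least 4.4-fold lower number from compound 1 to compound 2 (0.64 log units; beyond the scatter) and an at least 1.9-fold lower number from compound 1 to compound 3 (0.28 log units; that floor lies within the scatter) are floors, not sizes, as noted in the limit of > 100000 nM in this assay, at which 1 of the 3 values shown sits.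

Compound 4 `CC(C)=CC[C@@H](OCC(C)O)C1=CC(=O)c2c(O)ccc(O)c2C1=O` differs from compound 3 by 2-hydroxypropyl in place of (2-ethyl-2-hydroxybutyl)carbonyl on an oxygen on a saturated carbon. Going by the values given here, this is the reverse of the one step measured with a number at both ends, from compound 2 to compound 3, and the entering 2-hydroxypropyl group is the one carried by compound 2. A lower number in this assay of about that size is therefore expected, taken with caution since the measured step is only modestly beyond the scatter.

For compound 4 the estimate in this assay is 22500 nM, with a range from 10000 nM to 50000 nM. The expected step is a 2.3-fold lower number from compound 3 to compound 4 (0.36 log units; beyond the scatter).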

Compound 4, half-maximal inhibitory concentration: 24700 nM
Compound 4: the middle estimate sits 1.1-fold (0.04 log units) below what was measured; measured number inside the range.
By their numbers in this assay, from the lowest: compounds 2 and 4 (each within the scatter of the next); then compound 3. At a limit, above all of these: compound 1.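

The 2-hydroxypropyl group now has a second reading on this oxygen, and a 2.1-fold lower number from compound 3 to compound 4 (0.32 log units; beyond the scatter) shows that the gap to the (2-ethyl-2-hydroxybutyl)carbonyl group does not rest on compound 2 alone. With a 1.1-fold higher number from compound 2 to compound 4 (0.04 log units; within the scatter), compound 2 and compound 4 cannot be told apart in this assay, but this comparison cannot settle what the configuration at that stereocentre contributes: the fact that one of compounds 2 and 4 is drawn with a defined configuration and the other without, at the place where they differ. Compound 1 remains at a limit, not a number, so an at least 4.0-fold lower number from compound 1 to compound 4 (0.60 log units; beyond the scatter) gives a floor and not a size: the limit of > 100000 nM in this assay, at which 1 of the 4 values shown sits.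

The compounds shown leave open how the opposite, S configuration at the 2-hydroxypropyl stereocentre would read. Also open, going by these compounds, is how a longer chain, an amine or a carboxylic acid in that group would compare on the shared core.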